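Half-life on leaving the amide of compound 3

This account rests on a few compounds, and the source may have more. Where it says the series, first, only, none or still open, it means among the compounds named here.

Compound 1 `CC(C)CCn1nc(-c2cccs2)c(O)c(C2=NS(=O)(=O)c3cc(OCC(N)=O)ccc3N2)c1=O`: 0.383 h
Compound 2 `CC(C)CCn1nc(-c2cccs2)c(O)c(C2=NS(=O)(=O)c3cc(CCC(N)=O)ccc3N2)c1=O`: > 1 h (a limit of the assay)
Compound 3 `CC(C)CCn1nc(-c2cccs2)c(O)c(C2=NS(=O)(=O)c3cc(NC(=O)C4CC4)ccc3N2)c1=O`: 0.0833 h

These three compounds share one core, differ in a single group on an aromatic carbon, and were all tested in an in vitro ADME assay on microsomes from liver (Homo sapiens) for metabolic stability, tested at 5 uM; on this read-out lower numbers stand for a shorter-lived compound and higher numbers for a longer-lived compound. Compound 3, at 0.0833 h, has the lowest number of the three. The entry for compound 2 is a limit and not a number.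

The next compound is compound 4 `CC(C)CCn1nc(-c2cccs2)c(O)c(C2=NS(=O)(=O)c3cc(C4CCCC4=O)ccc3N2)c1=O`. It carries 2-oxocyclopentyl in place of (cyclopropylcarbonyl)amino on an aromatic carbon.

Three measured steps at this place bear on the change. Both steps that end at compound 3 go down and lie beyond the scatter: a 4.6-fold lower number from compound 1 to compound 3 (0.66 log units; beyond the scatter), a modest one, and an at least 12-fold lower number from compound 2 to compound 3 (1.07 log units; beyond the scatter), a large one. The third, an at least 2.6-fold higher number from compound 1 to compound 2 (0.41 log units; beyond the scatter), shows that the number also moves between the two carbamoyl-bearing groups. None of them tests 2-oxocyclopentyl itself, so the size of the change remains uncertain.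

Since compound 3 sits low at 0.0833 h, removing its group is expected to raise the number in this assay by a modest step. The expected step is a 3.6-fold higher number from compound 3 to compound 4 (0.56 log units; beyond the scatter). For compound 4 the estimate is 0.3 h, with an expected range from 0.1 h to 0.9 h.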

Compound 4, half-life: 0.733 h
For compound 4 the middle estimate is 2.4-fold (0.39 log units) below the measured one; the range from low to high includes it.
By their numbers in this assay, from the lowest: compound 3; then compounds 1 and 4 (each within the scatter of the next). At a limit, above all of these: compound 2.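

In this assay, an 8.8-fold higher number from compound 3 to compound 4 (0.94 log units; beyond the scatter) shows that the low number of compound 3 does not carry over to 2-oxocyclopentyl, which is the same size in heavy atoms but has a five-membered carbon ring and no hydrogen-bond donor. Compound 1 and compound 2 both carry a group bearing a carbamoyl, whereas compound 4 does not. The comparison with compound 1 gives a 1.9-fold higher number from compound 1 to compound 4 (0.28 log units; within the scatter), so a group without a carbamoyl can reach the level of compound 1. The comparison with compound 2 gives only an at least 1.3-fold lower number from compound 2 to compound 4 (0.13 log units; that floor lies within the scatter), which leaves open whether compound 4 differs from it. The entry for compound 2 is a limit of the assay and not a number: the limit of > 1 h in this assay, at which 1 of the 4 values shown sits.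

The compounds shown leave open which part of the change carries the step, the loss of the amide nitrogen, the larger carbon ring or the placing of the carbonyl within that ring. A plain cyclopentyl, a cyclopentanone joined through an amide nitrogen or a ketone bearing a cyclopropyl could separate these parts, and a carboxylic acid or an amine at this place remains untested in the compounds shown here.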